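The source may report more compounds than this note shows. Statements on the series, on what has been measured and on what is new or still open speak of the compounds shown alone.

Measured so far: compound 1 `COc1ccc(C2C(O)C(=O)N2c2cc(OC)c(OC)c(OC)c2)cc1` with 12 nM in a functional assay on HT-29 cells (Homo sapiens) for inhibition, read by sulforhodamine B assay, with a stated time of 72 h; on this read-out lower numbers stand for stronger inhibition and higher numbers for weaker inhibition; compound 2 `CCSc1ccc(C2C(Oc3ccccc3)C(=O)N2c2cc(OC)c(OC)c(OC)c2)cc1` with 632 nM; compound 3 `CCOc1ccc(C2C(O)C(=O)N2c2cc(OC)c(OC)c(OC)c2)cc1` with 15 nM.

Compound 3 stands second highest of the three numbers, its nearest neighbour being compound 1 with a 1.3-fold higher number from compound 1 to compound 3 (0.10 log units; within the scatter), and its furthest compound 2. Compound 4 `CCSc1ccc(C2C(O)C(=O)N2c2cc(OC)c(OC)c(OC)c2)cc1` is not yet measured; it differs from compound 3 by ethylsulfanyl in place of ethoxy on an aromatic carbon. For the measured compounds named here, no measured step bears directly on this exchange: compound 2 carries the ethylsulfanyl group but differs from compound 3 in a second place as well, so its much higher number cannot be assigned to the sulfur alone. Going by the values given here, the one measured step, a 1.3-fold higher number from compound 1 to compound 3 (0.10 log units; within the scatter), is unrelated in kind. Compound 4 is therefore expected to give 80 nM, within 20 nM to 400 nM, an expected step of a 5.3-fold higher number from compound 3 to compound 4 (0.73 log units; beyond the scatter), leaning weaker with wide uncertainty.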

Compound 4, half-maximal inhibitory concentration: 12 nM
For compound 4 the middle estimate is 6.7-fold (0.82 log units) above the measured one; measured number outside the range, below it.
By their numbers in this assay, from the lowest: compounds 1, 4 and 3 (each within the scatter of the next); then compound 2.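

In this assay, ethylsulfanyl in place of ethoxy on the aromatic carbon leaves the number within the scatter (a 1.3-fold lower number from compound 3 to compound 4 (0.10 log units; within the scatter)), and the same holds for ethylsulfanyl in place of methoxy (no change at the digits printed from compound 1 to compound 4 (within the scatter)). The large gap belongs to the other place, with hydrogen in place of phenyl on the oxygen (a 53-fold lower number from compound 2 to compound 4 (1.72 log units; beyond the scatter)). No measurement here gives a reason for either result. On these data alone, whether an amine or a longer chain such as butylsulfanyl on the aromatic carbon would keep the number stays open. So does the effect of a methyl group in place of phenyl on that oxygen.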